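An isopropyl group on the side chain of compound 3

The source may hold more compounds than are shown below. What is called first, only, known or untested is meant among the compounds shown, and "the series" means these compounds.

Compound 1 `CC1=CCC[C@H]2[C@](C)(CC3=CC(=O)C=CC3=O)[C@@H](C)CC[C@]12C`: > 200000 nM, a limit of the assay
Compound 2 `CC1=CCC[C@H]2[C@](C)(CC3=CC(=O)C=C(NCCC(=O)O)C3=O)[C@@H](C)CC[C@]12C`: 80800 nM
Compound 3 `CC1=CCC[C@H]2[C@](C)(CC3=CC(=O)C=C(NCC(=O)O)C3=O)[C@@H](C)CC[C@]12C`: 183000 nM

These values come from an ADME assay on MRC5 cells (Homo sapiens) for cytotoxicity, read by MTT assay, with a stated time of 72 h; a lower number here means a stronger inhibitor, a higher number a weaker inhibitor. Of the two values that are actual numbers, the higher belongs to compound 3, and the gap to its nearest neighbour is a 2.3-fold higher number from compound 2 to compound 3 (0.36 log units; beyond the scatter). Against the limit of compound 1, the measured step is an at least 1.0-fold lower number from compound 1 to compound 3 (0.03 log units; that floor lies within the scatter).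

Compound 4 `CC1=CCC[C@H]2[C@](C)(CC3=CC(=O)C=C(N[C@@H](C(=O)O)C(C)C)C3=O)[C@@H](C)CC[C@]12C` differs from compound 3 in one place: isopropyl in place of hydrogen on a saturated chain carbon bound to an amine nitrogen and a carbonyl carbon. Isopropyl stands in place of hydrogen on a saturated chain carbon bound to an amine nitrogen and a carbonyl carbon.

Among the compounds with values here, no measured compound carries this group, so the guide is weak. The closest evidence is another change in the same side chain, a 2.3-fold higher number from compound 2 to compound 3 (0.36 log units; beyond the scatter), which shows that compound 2 has the lower number at 80800 nM. On that basis, a modest move to a lower number is expected in this assay, though a step within the scatter remains possible. The expected change is a 1.7-fold lower number from compound 3 to compound 4 (0.24 log units; within the scatter). For compound 4 the estimated value is 105000 nM, with an expected range of 40000 nM to 200000 nM.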

Compound 4, half-maximal inhibitory concentration: 85400 nM
For compound 4 the middle estimate is 1.2-fold (0.09 log units) above the measured one; measured number inside the range.
By their numbers in this assay, from the lowest: compounds 2 and 4 (each within the scatter of the next); then compound 3. At a limit, above all of these: compound 1.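

Within the data shown here, at the saturated chain carbon bound to an amine nitrogen and a carbonyl carbon, the earlier compounds carried only hydrogen, and in this assay isopropyl there gives a 2.1-fold lower number from compound 3 to compound 4 (0.33 log units; beyond the scatter), which shows that this carbon responds to substitution. Branching at this carbon and the longer chain reach one level, as the 1-carboxy-2-methylpropyl and 2-carboxyethyl groups on the amine nitrogen give a 1.1-fold higher number from compound 2 to compound 4 (0.02 log units; within the scatter). Compound 1 stands at a limit of the assay, so an at least 2.3-fold lower number from compound 1 to compound 4 (0.36 log units; beyond the scatter) is only a floor: the limit of > 200000 nM in this assay, at which 1 of the 4 values shown sits.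

From the compounds shown here alone, whether a methyl or a benzyl group on this carbon would give a number different from that of isopropyl stays open. So does the outcome of replacing the carboxylic acid of the side chain with an amide or an ester.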